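Aminothiophene series: aryl swap and adenosine A3 displacement

A few compounds are considered here, and "the series" means these few. Any claim that something is new, unique, unknown or untested is made for them only; others in the source may bear on it.

Measured compounds:
compound 1 `CC(C)(C)Cc1csc(N)c1C(=O)c1ccc(Cl)cc1` gives 5%
compound 2 `Cc1sc(N)c(C(=O)c2ccc(Cl)cc2)c1-c1ccccc1` gives 1%
compound 3 `CC(C)(C)Cc1c(-c2ccc(F)cc2)sc(N)c1C(=O)c1ccc(Cl)cc1` gives 9%

In an assay on CHO cells for displacement of a labelled ligand from adenosine receptor A3 (Homo sapiens), read by scintillation counting, tested at 10 uM (a higher number here means more inhibition at the concentration tested (going by the name of the read-out), a lower number less inhibition), compound 3 gives 9%, while compound 1 gives 5% and compound 2 gives 1%; all three numbers lie within the usual scatter of one another, so no ranking among them is supported.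

Compound 4 `CC(C)(C)Cc1c(-c2c(F)cccc2F)sc(N)c1C(=O)c1ccc(Cl)cc1` has not yet been measured. Relative to compound 3 the change is 2,6-difluorophenyl in place of 4-fluorophenyl on an aromatic carbon. Among the compounds with values here, the only measured step in this region, a number 4 percentage points higher from compound 1 to compound 3 (within the scatter), adds the 4-fluorophenyl group and stays within the scatter. No step compares two fluorination patterns on that ring, so the data give no reason to expect a shift beyond the scatter in this assay.

Compound 4 is therefore expected to give 8% in this assay, between 0% and 20%, a step of a number 1 percentage points lower from compound 3 to compound 4 (within the scatter) estimated as negligible.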

Compound 4, a percentage reported as inhibition, at one concentration (the size of the read-out at that concentration, not a potency): 1%
Compound 4: middle estimate off by 7 percentage points, on the high side, within the range that was stated.
By their numbers in this assay, from the lowest: compounds 2, 4, 1 and 3 (each within the scatter of the next).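

In this assay, the switch to 2,6-difluorophenyl gives a number 8 percentage points lower from compound 3 to compound 4 (within the scatter), so changing the fluorination pattern on this ring produces no readable shift at this position. Against hydrogen on the same carbon, the group gives a number 4 percentage points lower from compound 1 to compound 4 (within the scatter), so neither aryl group shown separates from hydrogen here. No evidence bears on this result.

No step shown leaves the scatter, so it remains open whether any substituent at this position can do so. A carboxylic acid or a morpholine on this aryl ring remains untested in the compounds shown.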